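The source may report more compounds than this note shows. Statements on the series, on what has been measured and on what is new or still open speak of the compounds shown alone.

Four compounds share one core and differ only in the aromatic group carried at the far end. They are compound 1 `C=C1C[C@]23C[C@@]1(O)CC[C@H]2c1ccc(O)c(C)c1[C@@H]3Cn1cc(-c2ccccn2)nn1`, compound 2 `C=C1C[C@]23C[C@@]1(O)CC[C@H]2c1ccc(O)c(C)c1[C@@H]3Cn1cc(-c2ccc(C(F)(F)F)cc2)nn1`, compound 3 `C=C1C[C@]23C[C@@]1(O)CC[C@@H]2c1cccc(C)c1[C@@H]3Cn1cc(-c2ccc(OC)cc2)nn1` and the still unmeasured compound 4 `C=C1C[C@]23C[C@@]1(O)CC[C@@H]2c1cccc(C)c1[C@@H]3Cn1cc(-c2ccc(F)cc2)nn1`. In a functional assay on A549 cells (Homo sapiens) for cytotoxicity, read by MTT assay, with a stated time of 4 days (a lower number here means a stronger inhibitor, a higher number a weaker inhibitor), compound 1 reaches only the limit of the assay, > 20000 nM, so no number is known for it. In this assay compound 2 gives 10400 nM. The exchange from compound 1 to compound 2 shows an at least 1.9-fold lower number from compound 1 to compound 2 (0.28 log units; that floor lies within the scatter). Compound 3 likewise stands at the limit of this assay, > 20000 nM, and only that bound is known for it. Two of the three values shown sit at this limit (the limit of > 20000 nM in this assay, at which 2 of the 3 values shown sit).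

Compound 4 differs from compound 3 by fluoro in place of methoxy on an aromatic carbon. Among the measured compounds shown here, no measured step trades a methoxy for a fluoro; the only measured step, from compound 1 to compound 2, changes the same aromatic group and stays within the scatter. On that basis compound 4 is expected to remain weak in this assay, with an expected step of a number no higher from compound 3 to compound 4 (the limit leaves the size open), meaning no change beyond the scatter. Compound 4 is therefore estimated at 20000 nM in this assay, within a range from 8000 nM to 50000 nM, and it may well again report only a limit.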

Compound 4, half-maximal inhibitory concentration: > 20000 nM
Compound 4: only a limit was reported; the forecaster's own chance of this, stated with the estimate: 60%; the middle value lies on the limit itself.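

Compound 4 reports only a limit in this assay, > 20000 nM. Compound 3 also stands at a limit, so no step between the two can be read: the limit of > 20000 nM in this assay, at which 3 of the 4 values shown sit.

The compounds shown leave open how far compound 1, compound 3 and compound 4 lie beyond that limit, and whether 4-fluorophenyl and 4-methoxyphenyl differ at all in this assay.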